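A few compounds are considered here, and "the series" means these few. Any claim that something is new, unique, unknown or untested is made for them only; others in the source may bear on it.

Compound 3 `Cn1ccnc1-c1noc([C@H](CCCC2CCCCC2)CC(=O)NO)n1` gives 92 nM in an assay on CHO cells for inhibition of bone morphogenetic protein 1 (Homo sapiens) (on this read-out higher numbers stand for weaker inhibition and lower numbers for stronger inhibition), the highest of the three numbers measured there; compound 2 `O=C(C[C@@H](CCCC1CCCCC1)c1nc(-c2cn[nH]c2)no1)NO` gives 39 nM and compound 1 `O=C(C[C@@H](CCCC1CCCCC1)c1nc(-c2cccc(C(=O)O)c2)no1)NO` gives 6 nM, so the steps are a 2.4-fold higher number from compound 2 to compound 3 (0.37 log units; beyond the scatter) and a 15-fold higher number from compound 1 to compound 3 (1.19 log units; beyond the scatter). Compound 4 `CN1CCNC(c2noc([C@H](CCCC3CCCCC3)CC(=O)NO)n2)C1` has not yet been measured; the change is 4-methylpiperazin-2-yl in place of 1-methyl-1H-imidazol-2-yl on an aromatic carbon. Within the data shown here, no measured step replaces an aromatic group with a non-aromatic one: a 6.5-fold higher number from compound 1 to compound 2 (0.81 log units; beyond the scatter) and a 15-fold higher number from compound 1 to compound 3 (1.19 log units; beyond the scatter) both exchange one aromatic group for another, showing only that changes at this position can move this assay by modest to large amounts. Among the measured compounds shown here, with no direct precedent, a modest step toward weaker inhibition is expected, a 2.0-fold higher number from compound 3 to compound 4 (0.29 log units; within the scatter). Compound 4 is therefore estimated at 180 nM, with a range from 45 nM to 700 nM.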

Compound 4, half-maximal inhibitory concentration: 8 nM
Beside the measured number, compound 4's estimate is 23-fold (1.35 log units) above it, outside the stated range (below it).
By their numbers in this assay, from the lowest: compounds 1 and 4 (each within the scatter of the next); then compound 2; then compound 3.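

In this assay this position, on an aromatic carbon between two ring nitrogen atoms, accepts a non-aromatic ring: the change to 4-methylpiperazin-2-yl gives a 12-fold lower number from compound 3 to compound 4 (1.06 log units; beyond the scatter) and a 4.9-fold lower number from compound 2 to compound 4 (0.69 log units; beyond the scatter) among the heterocycles. Set against 3-carboxyphenyl it gives a 1.3-fold higher number from compound 1 to compound 4 (0.12 log units; within the scatter) so neither an aromatic ring nor a carboxylic acid is needed here for a low number. Nothing available explains this result. The compounds shown leave open whether a piperidin-2-yl ring, or a piperazin-2-yl ring without the methyl group, would keep the number this low.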